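Series notes: methyl in place of hydrogen on an oxygen

The source may report more compounds than this note shows. Statements on the series, on what has been measured and on what is new or still open speak of the compounds shown alone.

Measured so far:
compound 1 `COc1cc(Cl)cc(-c2nn(-c3cccc(NC(=O)Nc4cccc(C(F)(F)F)c4)c3)cc2-c2ccncc2)c1`: 0.3%
compound 2 `COc1cc(Cl)cc(-c2nn(-c3cccc(NC(=O)c4cccc(C(F)(F)F)c4)c3)cc2-c2ccncc2)c1`: 39.4%
compound 3 `O=C(Nc1cccc(-n2cc(-c3ccncc3)c(-c3cc(O)cc(Cl)c3)n2)c1)c1cc(C(F)(F)F)cc(C(F)(F)F)c1`: 23%

In a functional assay on MCF7 cells (Homo sapiens) for inhibition, read by sulforhodamine B assay, with a stated time of 48 h, tested at 10 uM (on this read-out higher numbers stand for a weaker effect at the one concentration tested and lower numbers for a stronger effect), compound 1 gives 0.3% and compound 2 gives 39.4%; compound 3 gives 23%, the second highest of the three numbers, nearer to compound 2 than to compound 1, both gaps beyond the scatter. Among the compounds with values here, the single measured step is a number 39.1 percentage points higher from compound 1 to compound 2 (beyond the scatter), a change at the carbonyl carbon. Compound 4 `COc1cc(Cl)cc(-c2nn(-c3cccc(NC(=O)c4cc(C(F)(F)F)cc(C(F)(F)F)c4)c3)cc2-c2ccncc2)c1` differs from compound 3 by methyl in place of hydrogen on an oxygen on an aromatic ring. Within the data shown here, no measured step touches that oxygen, so nothing here speaks for a shift in this assay in either direction; the expected step is none beyond the scatter, no change at the digits printed from compound 3 to compound 4 (within the scatter). Compound 4 is therefore estimated at 23%, with a range of 5% to 45%.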

Compound 4, a percentage reported as activity, at one concentration (the size of the read-out at that concentration, not a potency): 57.8%
Beside the measured number, compound 4's estimate is 34.8 percentage points below it; measured number above the stated range.
By their numbers in this assay, from the lowest: compound 1; then compound 3; then compound 2; then compound 4.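

In this assay, the oxygen on the aromatic ring is not a silent place: hydroxy to methoxy gives a number 34.8 percentage points higher from compound 3 to compound 4 (beyond the scatter), so within this pair the free hydroxy goes with the stronger effect. The added trifluoromethyl on an aromatic carbon also weakens the effect among the methoxy amides, with a number 18.4 percentage points higher from compound 2 to compound 4 (beyond the scatter). Nothing available gives a reason for either step. On these data alone, whether an ethoxy group or an amine at this place follows the same direction remains open. So does whether hydroxy would also give a stronger effect alongside the (3-(trifluoromethyl)phenyl)amino group of compound 1.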